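Notes on the step from compound 3 to compound 4

A few compounds are considered here, and "the series" means these few. Any claim that something is new, unique, unknown or untested is made for them only; others in the source may bear on it.

Measured in a functional assay on PC-3 cells (Homo sapiens) for antiproliferative activity, read by MTT assay, with a stated time of 72 h; on this read-out lower numbers stand for stronger inhibition and higher numbers for weaker inhibition:
- compound 1 `O=C(N/N=C/c1ccc([N+](=O)[O-])cc1)Nc1ccc(Oc2ccnc3[nH]ccc23)c(F)c1`: 150 nM
- compound 2 `CC(C)(C)c1cc(/C=N/NC(=O)Nc2ccc(Oc3ccnc4[nH]ccc34)c(F)c2)cc(C(C)(C)C)c1O`: 10400 nM
- compound 3 `O=C(N/N=C/c1ccc([N+](=O)[O-])cc1)Nc1ccc(Oc2ccnc3[nH]ccc23)cc1`: 28100 nM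

Compound 3 has the highest number of the three, with compound 2 nearest to it. Compound 4 `CN(C)CCCn1cccc1/C=N/NC(=O)Nc1ccc(Oc2ccnc3[nH]ccc23)cc1` differs from it in one group: 1-(3-(dimethylamino)propyl)-1H-pyrrol-2-yl in place of 4-nitrophenyl on a carbon with a double bond to nitrogen. That is 1-(3-(dimethylamino)propyl)-1H-pyrrol-2-yl in place of 4-nitrophenyl on a carbon with a double bond to nitrogen. Among the compounds with values here, no measured step covers this change. The only one, a 190-fold higher number from compound 1 to compound 3 (2.27 log units; beyond the scatter), is hydrogen in place of fluoro on an aromatic carbon, and it is large. With fluoro present, different groups on that carbon give a wide spread: compound 1 gives 150 nM and compound 2 gives 10400 nM. A lower number is expected, as compound 3 stands at 28100 nM at the top of the set. The expected move is a 4.7-fold lower number from compound 3 to compound 4 (0.67 log units; beyond the scatter), with much uncertainty. For compound 4 the estimate is 6000 nM, with an expected range of 800 nM to 40000 nM.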

Compound 4, half-maximal inhibitory concentration: 5150 nM
The estimate for compound 4 lay 1.2-fold (0.07 log units) above the measured number; the range from low to high includes it.
By their numbers in this assay, from the lowest: compound 1; then compound 4; then compound 2; then compound 3.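

Without fluoro on the core, the group on the carbon with a double bond to nitrogen still moves the result in this assay: a 5.5-fold lower number from compound 3 to compound 4 (0.74 log units; beyond the scatter). This modest step stays far smaller than a 190-fold higher number from compound 1 to compound 3 (2.27 log units; beyond the scatter), so here the change of group does not match the effect of the fluoro change. The step swaps ring and chain together, and nothing available explains the shift.

On these data alone, it remains open whether adding fluoro to compound 4 would lower its number. Separating ring from chain would need an unsubstituted pyrrole or a longer chain ending in morpholine.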